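The source may hold more compounds than are shown below. What is called first, only, known or untested is meant among the compounds shown, and "the series" means these compounds.

Working notes on the series.

The two measured compounds are compound 1 `CCCCS(=O)(=O)c1sc2nc(-c3nccs3)cc(-c3cnc(C)n3C)c2c1N` and compound 2 `CCCC[S+]([O-])c1nc2ccc(-c3cccs3)nc2s1`. In an assay for inhibition of 15-hydroxyprostaglandin dehydrogenase [NAD(+)] (Homo sapiens), read by fluorescence, with a stated time of 15 min, in the presence of a further agent that is not named here (on this read-out higher numbers stand for weaker inhibition and lower numbers for stronger inhibition), compound 1 gives 32 nM, the lower of the two numbers recorded so far. In this assay compound 2 gives 1230 nM, a higher number, beyond the usual scatter of repeated measurements. Compound 2 differs from compound 1 in several places at once, so no single change is tied to the gap between the two values.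

The next compound, compound 3 `COCCC[S+]([O-])c1sc2nc(-c3nccs3)cc(-c3cnc(C)n3C)c2c1N`, is still to be measured. It is built on the shared core of compound 1 with one change: a group of 7 heavy atoms (4 carbon, 2 oxygen, 1 sulfur; no ring) in place of a group of 7 heavy atoms (4 carbon, 2 oxygen, 1 sulfur; no ring), on an aromatic carbon. The group that leaves and the group that enters hold the same atoms, joined differently, so the change is a rearrangement rather than a gain or loss of heavy atoms.

Going by the values given here, no pair of measured compounds differing in this one place is available, so the size of the step is open. The expectation is a modest move toward a higher number, from compound 1 to compound 3 of a 1.9-fold higher number from compound 1 to compound 3 (0.27 log units; within the scatter), within or just beyond the scatter. Compound 3 is estimated at 60 nM, with a range from 15 nM to 250 nM.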

Compound 3, half-maximal inhibitory concentration: 3.3 nM
Compound 3: middle estimate off by 18-fold (1.26 log units), on the high side; the whole stated range lies above it.
By their numbers in this assay, from the lowest: compound 3; then compound 1; then compound 2.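

At this position, on an aromatic carbon of the five-membered ring next to the ring sulfur and next to the ring atom that bears an amino group, rearranging the atoms of the substituent is enough to move the result. In this assay, going by these compounds alone, putting the rearranged group in place of butylsulfonyl gives a 9.7-fold lower number from compound 1 to compound 3 (0.99 log units; beyond the scatter), a step beyond the scatter and the first single-place comparison. The two groups have the same counts of heavy atoms, hydrogen-bond donors and hydrogen-bond acceptors, so those counts do not separate them, and the lower number goes with how the atoms are joined; no measurement bearing on the origin of the step is available.

The compounds shown do not separate the state of the sulfur from the placement of the oxygen in the chain, a comparison that butylsulfinyl on the shared core would supply. Also open, from the compounds shown here alone, is how this position responds to a longer chain or to a chain ending in an amine or a carboxylic acid.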